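Allyl Exchanged for Cyclopentyl: An Expected Lipophilicity Rise

A few compounds are considered here, and "the series" means these few. Any claim that something is new, unique, unknown or untested is made for them only; others in the source may bear on it.

Of the compounds shown here, two built on the same core have been measured in a physicochemical assay for lipophilicity; a higher number here means a more lipophilic compound, a lower number a more polar compound. Compound 1, `Brc1ccc(Br)c(N(CC2CC2)C2=NCCN2)c1`, gives -0.52. Compound 2, `C=CCN(C1=NCCN1)c1c(Br)cccc1Br`, gives -0.75. These two numbers sit within the usual scatter of each other, so on the numbers shown compound 2 stands beside compound 1 rather than apart from it; no real gap can be claimed between them.

Compound 3, `Brc1cccc(Br)c1N(C1=NCCN1)C1CCCC1`, has not yet been measured in this assay. It differs from compound 2 in one place: cyclopentyl in place of allyl on a nitrogen on an aromatic ring. The group that enters carries more carbon than the group that leaves, and it closes into a ring where the leaving group was an open chain with one double bond. Within the data shown here, no measured pair here makes this exact exchange, so the size of the effect has to be estimated rather than read off.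

Compound 3 is expected to come out at 0.2, with a likely range from -0.3 to 0.7. The expected step, a number 0.95 log units higher from compound 2 to compound 3 (beyond the scatter), is estimated to lie beyond the scatter, towards the more lipophilic side, because compound 2 starts from -0.75 and the added carbon is anticipated to push the number upward.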

Compound 3, distribution coefficient: -0.29
Compound 3: middle estimate off by 0.49 log units, on the high side; low and high end bracket the measured number.
By their numbers in this assay, from the lowest: compounds 2, 1 and 3 (each within the scatter of the next, the first and the last beyond it).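

Among these compounds, this pair gives the first measured exchange at this position: with cyclopentyl in place of allyl on a nitrogen on an aromatic ring, this assay shows a number 0.46 log units higher from compound 2 to compound 3 (beyond the scatter) and this modest step lies beyond the scatter. Compound 1 and compound 2 could not show that the number answers to the group on this nitrogen, as they differ in more than one place and their values lie within the scatter of each other. No measurement shown here accounts for the size of the step.

The exchange alters several things at once, replacing an open chain with one double bond by a five-membered ring of carbon only and raising the carbon count, so this single pair cannot separate the contribution of the ring, the double bond or the added carbon. An open pentyl chain on the same nitrogen would help to separate ring from carbon count, while an amine or a carboxylic acid placed on that group would show how far the number moves when the added atoms are not carbon alone.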